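The source may hold more compounds than are shown below. What is called first, only, known or untested is meant among the compounds shown, and "the series" means these compounds.

Compound 1 `O=C1NCCN1CCCCN1CCC(c2cn(-c3ccc(F)cc3)c3ccc(Cl)cc23)CC1` and compound 2 `Fc1ccc(-n2cc(C3=CCNCC3)c3cc(Cl)ccc32)cc1` share a core, and both were tested in a functional assay on the whole organism for inhibition, with Rattus norvegicus as the target; on this read-out higher numbers stand for an effect only at larger amounts of compound and lower numbers for an effect already at smaller amounts. In this assay compound 2 gives 1.5 umol/kg. For compound 1 the result in this assay is only a limit, > 2.2 umol/kg. This is the limit of > 2.2 umol/kg in this assay, at which 1 of the 2 values shown sits. Compound 3 `O=C1NCCN1CCCCCCN1CCC(c2cn(-c3ccc(F)cc3)c3ccc(Cl)cc23)CC1` has not yet been measured. It differs from compound 1 in one place: 2-(2-oxoimidazolidin-1-yl)ethyl in place of 2-oxoimidazolidin-1-yl on a saturated chain carbon, four bonds along the chain from an amine nitrogen in a ring. Going by the values given here, no measured step links such a lengthening of the chain to a shift in this assay, so no change beyond the usual scatter is expected. Compound 3 is estimated at 3 umol/kg, between 1.5 umol/kg and 8 umol/kg. That expectation corresponds to a step that the limit leaves unreadable from compound 1 to compound 3.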

Compound 3, dose for half-maximal effect: > 2.2 umol/kg
Compound 3: a limit, no number; the forecaster's own chance of this, stated with the estimate: 60%; the middle value does not contradict the limit.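

Compound 1 and compound 3 each give only a limit, so no step between them can be read: the limit of > 2.2 umol/kg in this assay, at which 2 of the 3 values shown sit.

On these data alone, whether 2-(2-oxoimidazolidin-1-yl)ethyl in place of 2-oxoimidazolidin-1-yl shifts the result in this assay, and in which direction, stays open.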